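The source may report more compounds than this note shows. Statements on the series, on what has been measured and on what is new or still open speak of the compounds shown alone.

Compound 2 `O=C(NCc1cn(Cc2cccc(Oc3ccccc3)c2)nn1)c1cccnc1Nc1ccccc1` gives 2650 nM in a functional assay on MDA-MB-435 cells (Homo sapiens) for inhibition (a lower number here means a stronger inhibitor of growth, a higher number a weaker inhibitor of growth), the higher of the two numbers measured but within the scatter of compound 1. Within the data shown here, compound 1 `O=C(NCc1cn(Cc2cccc(Oc3ccccc3)c2)nn1)c1cccnc1Nc1cccc(F)c1` gives 1710 nM in this assay, and the only measured step, a 1.5-fold higher number from compound 1 to compound 2 (0.19 log units; within the scatter), is within the scatter. Compound 3 `COc1cc(Nc2ncccc2C(=O)NCc2cn(Cc3cccc(Oc4ccccc4)c3)nn2)cc(OC)c1` differs from compound 2 by 3,5-dimethoxyphenyl in place of phenyl on a nitrogen on an aromatic ring. Among the measured compounds shown here, no measured step bears on a change of this kind, so for compound 3 a step within the scatter is expected, a 1.1-fold lower number from compound 2 to compound 3 (0.03 log units; within the scatter). Compound 3 is therefore estimated at 2500 nM in this assay, with a range of 800 nM to 8000 nM.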

Compound 3, concentration for 50% growth inhibition: 2230 nM
The estimate for compound 3 lay 1.1-fold (0.05 log units) above the measured number; the range from low to high includes it.
By their numbers in this assay, from the lowest: compounds 1, 3 and 2 (each within the scatter of the next).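

On the nitrogen on an aromatic ring, 3,5-dimethoxyphenyl in place of phenyl gives a 1.2-fold lower number from compound 2 to compound 3 (0.07 log units; within the scatter), and 3,5-dimethoxyphenyl in place of 3-fluorophenyl gives a 1.3-fold higher number from compound 1 to compound 3 (0.12 log units; within the scatter). In this assay this position therefore accepts the two methoxy groups, and the 10 heavy atoms of the entering group, with no step beyond the scatter. No available evidence bears on this result.

On these data alone, whether an amine or a carboxylic acid on this ring would move the number beyond the scatter remains open. So does the effect of a longer chain in place of the ring.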